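This account rests on a few compounds, and the source may have more. Where it says the series, first, only, none or still open, it means among the compounds named here.

Three compounds with a shared core have been examined in a functional assay on RAW264.7 cells (Mus musculus) for inhibition, read by Griess assay, with a stated time of 24 h; on this read-out higher numbers stand for weaker inhibition and lower numbers for stronger inhibition. Compound 1 `CC(C)C1=C[C@@H]2[C@@H](CC[C@@H]2C)[C@@](C)(O)CC1` gives 11400 nM in this assay. Compound 2 `CC(C)C1=C[C@H]2[C@@H](CC[C@]2(C)O)[C@](C)(O)CC1` gives 4300 nM in this assay. Compound 3 `CC(C)=C1C[C@H]2[C@@H](CC[C@]2(C)O)C(CO)=CC1=O` gives 12900 nM in this assay. Among these three numbers, compound 3 lies within the usual scatter of compound 1, so nothing separates the two, while compound 2 sits at a lower number than compound 3 by a margin that is beyond the scatter.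

The account now turns from compound 3 to compound 4 `CC1=CC(=O)C(=C(C)C)C[C@H]2[C@H]1CC[C@]2(C)O`, which has not yet been measured in this assay. The two differ in one place: hydrogen in place of hydroxy on a saturated chain carbon bound to a double-bonded ring carbon. Going by the values given here, no pair of measured compounds in this set differs by this same change, so the data give no direct guide to what the change does. The core stays as it is in compound 3, and only a hydroxy is exchanged for hydrogen.

For this reason the step is expected to be small, most likely none beyond the scatter, with the direction uncertain, a 1.1-fold lower number from compound 3 to compound 4 (0.03 log units; within the scatter). In this assay compound 4 is therefore estimated to give 12000 nM, with a range from 5000 nM to 30000 nM.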

Compound 4, half-maximal inhibitory concentration: 13700 nM
For compound 4 the middle estimate is 1.1-fold (0.06 log units) below the measured one, and the stated range covers the measured number.
By their numbers in this assay, from the lowest: compound 2; then compounds 1, 3 and 4 (each within the scatter of the next).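

In this assay, the exchange of hydroxymethyl for methyl, on a saturated chain carbon bound to a double-bonded ring carbon, gives a 1.1-fold higher number from compound 3 to compound 4 (0.03 log units; within the scatter), so this pair cannot be told apart. It is the only pair shown that differs in one place, and it gives the first direct reading of any single change on the shared core: at this place and on this core, the hydroxy can give way to hydrogen with no change in the read-out beyond the scatter. Nothing available bears on why the exchange leaves the number within the scatter.

Going by these compounds, this one pair tests only hydroxy against hydrogen, so it remains open whether a carboxylic acid, an amine or a longer chain such as ethyl at this place would shift the number beyond the scatter. On these data alone, it also remains open whether the same exchange would be as quiet on a compound that differs elsewhere in the core, such as compound 2, which stands at 4300 nM.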